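A few compounds are considered here, and "the series" means these few. Any claim that something is new, unique, unknown or untested is made for them only; others in the source may bear on it.

Measured so far, in a functional assay on U-87MG ATCC cells (Homo sapiens) for cytotoxicity, read by MTT assay, with a stated time of 48 h; a lower number here means a stronger inhibitor, a higher number a weaker inhibitor:

compound 1, `C/C(=N/NC(=S)Nc1ccccc1)c1ccccn1`: 1.4 nM
compound 2, `CC(=NNC(=S)Nc1ccccc1)c1ccccn1`: 1.4 nM

Among the measured compounds shown here, compound 1 stands level with compound 2, its only measured neighbour; the step of no change at the digits printed from compound 1 to compound 2 (within the scatter) lies within the scatter, and the two differ solely in the fact that one of compounds 1 and 2 is drawn with a defined configuration and the other without, at the place where they differ. Compound 3, `C/C(=N/NC(=S)Nc1cccc(F)c1)c1ccccn1`, changes compound 1 by fluoro in place of hydrogen on an aromatic carbon. For the measured compounds named here, no measured step touches such a change; the single step known, no change at the digits printed from compound 1 to compound 2 (within the scatter), concerns only drawn configuration and is flat. Compound 3 is therefore expected to move only a little, a 1.4-fold higher number from compound 1 to compound 3 (0.15 log units; within the scatter). The estimate for compound 3 is 2 nM, within 0.5 nM to 8 nM.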

Compound 3, half-maximal inhibitory concentration: 18 nM
Compound 3: middle estimate off by 9.0-fold (0.95 log units), on the low side; the measured number lies above the stated range.
By their numbers in this assay, from the lowest: compounds 1 and 2 (each within the scatter of the next); then compound 3.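

In this assay, fluoro in place of hydrogen gives a 13-fold higher number from compound 1 to compound 3 (1.11 log units; beyond the scatter) and so shows that this aromatic carbon, meta to a large group, is sensitive to substitution, which the flat pair of compound 1 and compound 2 could not reveal. A single added fluorine atom is enough for a step beyond the scatter. Nothing available bears on the reason for this step. As far as these compounds go, it remains open whether chloro, methoxy or an amine at the same place would give a step of similar size and direction.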